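This account rests on a few compounds, and the source may have more. Where it says the series, first, only, none or still open, it means among the compounds named here.

Measured in an ADME assay on the whole organism (Mus musculus, strain C57BL/6J) for pharmacokinetics, with a stated time of 24 h, at a dose of 2 mg/kg by the intravenous route (on this read-out lower numbers stand for slow clearance and higher numbers for fast clearance), so far
- compound 1 `CCCCOc1nc(OCC(C)(C)O)c(-c2ccc(S(C)(=O)=O)cc2)cc1COCCO` gives 55.4 mL/min/kg
- compound 2 `CCCCOc1nc(OCC2COC2)c(-c2ccc(S(C)(=O)=O)cc2)cc1CO` gives 102 mL/min/kg
- compound 3 `CCCCOc1nc(OCC2(O)COC2)c(-c2ccc(S(C)(=O)=O)cc2)cc1CO` gives 68.6 mL/min/kg

Compound 3 stands at 68.6 mL/min/kg within the scatter of both compound 1 and compound 2, so its place among these numbers is not firmly settled. The next step leads to compound 4 `CCCCOc1nc(OCC2(O)CCC2)c(-c2ccc(S(C)(=O)=O)cc2)cc1CO` and is described by 1-hydroxycyclobutyl in place of 3-hydroxyoxetan-3-yl on a saturated chain carbon bound to an oxygen on an aromatic ring in the side chain. In words, 1-hydroxycyclobutyl takes the place of 3-hydroxyoxetan-3-yl on a saturated chain carbon bound to an oxygen on an aromatic ring.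

Among the measured compounds shown here, no measured step makes this exchange. The closest evidence is a 1.5-fold lower number from compound 2 to compound 3 (0.17 log units; within the scatter) as hydroxy replaces hydrogen on a saturated ring carbon, but this is a different change and gives only a loose guide. With compound 3 at 68.6 mL/min/kg as the starting point, no shift beyond the scatter is expected in this assay, and no direction can be favoured. The expected step is a 1.1-fold lower number from compound 3 to compound 4 (0.02 log units; within the scatter) and should be read as no real change. For compound 4 the estimate is 65 mL/min/kg with an expected range from 38 mL/min/kg to 110 mL/min/kg in this measurement.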

Compound 4, clearance: 100 mL/min/kg
Compound 4: the middle estimate sits 1.5-fold (0.19 log units) below what was measured; measured number inside the range.
By their numbers in this assay, from the lowest: compounds 1, 3, 4 and 2 (each within the scatter of the next).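

In this assay, 1-hydroxycyclobutyl in place of 3-hydroxyoxetan-3-yl on a saturated chain carbon bound to an oxygen on an aromatic ring gives a 1.5-fold higher number from compound 3 to compound 4 (0.16 log units; within the scatter), so this read-out does not separate the four-membered ring with one hetero atom from the four-membered ring of carbon only at this place. 1-Hydroxycyclobutyl in place of oxetan-3-yl at the same place gives a 1.0-fold lower number from compound 2 to compound 4 (0.01 log units; within the scatter), and with the earlier step of a 1.5-fold lower number from compound 2 to compound 3 (0.17 log units; within the scatter), all three pairs among compounds 2, 3 and 4 now lie within the scatter, so no difference can be assigned to either the ring atom or the hydroxy group in this small set. No measurement is available that bears on this result.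

The compounds shown leave open whether any group at this place can move clearance beyond the scatter, for example an amine, a carboxylic acid or a longer chain in place of the four-membered rings. They also leave open whether the oxetane and cyclobutane groups would stay indistinguishable on a core carrying a different group from the butoxy chain.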